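The source may hold more compounds than are shown below. What is called first, only, known or untested is meant among the compounds shown, and "the series" means these compounds.

Measured so far in an assay on isolated protein for inhibition of protein kinase C zeta type (Homo sapiens), with stated times of 1 h and 2.5 min, tested at 30 uM; on this read-out lower numbers stand for less inhibition and higher numbers for more inhibition at the one concentration tested (going by the name of the read-out):
Compound 1, `CCOC(=O)c1c(-c2ccc(OC)c(OC)c2)csc1N`, gives 100%.
Compound 2, `COc1ccc(-c2csc(N)c2C(=O)OCc2ccc(C#N)cc2)cc1OC`, gives 10%.
Compound 3, `CCOC(=O)c1c(-c2cccc(C)c2)csc1N`, gives 77%.

Compound 3 stands second of the three, beyond the scatter below compound 1 and beyond the scatter above compound 2. Compound 4, `CCOC(=O)c1c(-c2cccc(OC)c2)csc1N`, has not been measured; it differs from compound 3 by methoxy in place of methyl on an aromatic carbon. Among the measured compounds shown here, the only measured step, a number 90 percentage points lower from compound 1 to compound 2 (beyond the scatter), concerns a different place in the molecule and so gives no direct guide here. Compound 1, which carries methoxy groups on its ring, and compound 3 show only that both sit high. Compound 4 is therefore expected to stay high, with a step of a number 8 percentage points higher from compound 3 to compound 4 (within the scatter), and its estimated value is 85%, in the range 60% to 100%.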

Compound 4, a percentage reported as inhibition, at one concentration (the size of the read-out at that concentration, not a potency): 82%
Compound 4: the middle estimate sits 3 percentage points above what was measured; low and high end bracket the measured number.
By their numbers in this assay, from the lowest: compound 2; then compounds 3 and 4 (each within the scatter of the next); then compound 1.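

In this assay, methoxy in place of methyl on this aromatic carbon gives a number 5 percentage points higher from compound 3 to compound 4 (within the scatter), so the two groups are not told apart at this position. Hydrogen in place of methoxy on the ring gives a number 18 percentage points lower from compound 1 to compound 4 (beyond the scatter), a modest change, so losing one methoxy registers where swapping methyl for methoxy did not. No supporting data explain either step.

As far as these compounds go, whether an amine, a carboxylic acid or a longer chain on the same aromatic carbon would keep this inhibition stays open. Readings at a single concentration also leave true potency unsettled.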